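One Inverted Stereocentre at the Assay Limit

A few compounds are considered here, and "the series" means these few. Any claim that something is new, unique, unknown or untested is made for them only; others in the source may bear on it.

Compound 1 `Cc1nn(C[C@@H]2CO[C@H](CO)O2)c(=O)[nH]c1=O`: > 100000 nM, a limit
Compound 2 `Cc1nn(C[C@H]2CO[C@@H](CO)O2)c(=O)[nH]c1=O`: > 100000 nM, a limit

In a functional assay on L1210 cells (Mus musculus) (a lower number here means that less compound is needed, a higher number that more compound is needed for the effect), compound 2 gives > 100000 nM, which is a limit and not a number. Compound 3 `Cc1nn(C[C@@H]2CO[C@@H](CO)O2)c(=O)[nH]c1=O` differs from it in one place: the two compounds have the same atoms and bonds and differ only in configuration as drawn: 1 of 2 stereo elements differ; a stereocentre at a saturated ring carbon is drawn S in compound 2 and R in compound 3. Among the compounds with values here, the only measured step that bears on this, a step that the two limits leave unreadable from compound 1 to compound 2, has no readable size and rests on (the limit of > 100000 nM in this assay, at which 2 of the 2 values shown sit). Alongside (the fact that compounds 1 and 2 differ only in the configuration as drawn), it gives no sign that configuration shifts the result in this assay, so no step in either direction is expected. The estimated step is a number no higher from compound 2 to compound 3 (the limit leaves the size open). For compound 3, the expected value is 100000 nM, with an estimated range from 30000 nM to 200000 nM.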

Compound 3, half-maximal effective concentration: > 100000 nM
Compound 3: a limit, no number; the forecaster's own chance of this, stated with the estimate: 85%; the middle value lies on the limit itself.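

In this assay, within the data shown here, compounds 1, 2 and 3 all give limits and not numbers, so no step among them can be read. Whether configuration shifts the effect at all stays open: none of these compounds gives a number.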